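The compounds below may be only part of what the source reports. "The series", "measured", "known", "first", "only" and "open" are said of these compounds alone.

Measured in an ADME assay, at pH 3; on this read-out higher numbers stand for a longer-lived compound and lower numbers for a shorter-lived compound:
- compound 1 `COc1ccnc(C[S+]([O-])c2nc3cc(OC(F)F)ccc3[nH]2)c1C`: 0.0833 h
- compound 2 `COc1cc(C[S+]([O-])c2nc3cc(OC(F)(F)C(F)F)ccc3[nH]2)ncc1C`: 0.1 h
- compound 3 `COc1cc2[nH]c([S+]([O-])Cc3nccc(OC)c3OC)nc2cc1OC(F)F`: 0.25 h

Compound 3 stands highest of the three, and its gaps to compound 2 and to compound 1 both lie beyond the scatter of this assay. The next compound, compound 4 `COc1cc2[nH]c([S+]([O-])Cc3nccc(OC)c3C)nc2cc1OC(F)F`, keeps everything in compound 3 except one group: methyl in place of methoxy on an aromatic carbon.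

Among the compounds with values here, no measured pair isolates this change, so the evidence is indirect. Compound 1 also carries a methyl on that ring carbon and gives 0.0833 h, but it differs from compound 3 elsewhere as well. That points only loosely downward, so a small drop is expected, one that probably stays within the scatter. The expected change is a 1.6-fold lower number from compound 3 to compound 4 (0.19 log units; within the scatter). Compound 4 is estimated at 0.16 h, with an expected range of 0.08 h to 0.3 h.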

Compound 4, half-life: 0.1 h
Estimate against measurement, compound 4: 1.6-fold (0.20 log units) above, and the stated range covers the measured number.
By their numbers in this assay, from the lowest: compounds 1, 2 and 4 (each within the scatter of the next); then compound 3.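

In this assay, the swap of methoxy for methyl on this aromatic carbon, ortho to a large group and two atoms from the ring nitrogen, can now be read on its own, and it gives a 2.5-fold lower number from compound 3 to compound 4 (0.40 log units; beyond the scatter). Among the earlier compounds, no pair differed in one place only, so this is the first direct sign that the group on this carbon matters for the half-life at this pH. The other single change, methoxy in place of hydrogen on an aromatic carbon, gives a 1.2-fold higher number from compound 1 to compound 4 (0.08 log units; within the scatter), so of the two changes only the first stands clear of the scatter, and nothing at hand explains this difference.

The compounds shown leave open how an ethoxy group, a chlorine atom or an amine on this carbon would read in this assay. Going by these compounds, whether the step from methoxy to methyl holds with other groups elsewhere on the shared core also remains open.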